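From 2-methylphenyl to 2-methoxyphenyl

The source may report more compounds than this note shows. Statements on the series, on what has been measured and on what is new or still open speak of the compounds shown alone.

Going by the values given here, in a physicochemical assay for lipophilicity, read by HPLC, at pH 7.5 (a lower number here means a more polar compound, a higher number a more lipophilic compound), compound 2 `CC[C@@H](Nc1c(C#N)c(-c2ccc(-c3ccccc3C)cc2)nc2cnccc12)C(N)=O` gives 3, the higher of the two numbers so far. Compound 1 `CC[C@@H](Nc1c(C#N)c(-c2ccc(-c3ccccc3COC)cc2)nc2cnccc12)C(N)=O` gives 2.6, lower by more than the scatter.

The next structure is compound 3 `CC[C@@H](Nc1c(C#N)c(-c2ccc(-c3ccccc3OC)cc2)nc2cnccc12)C(N)=O`, with methoxy in place of methyl on an aromatic carbon, ortho to a large group: methoxy in place of methyl on an aromatic carbon.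

Among the compounds with values here, only one measured step bears on this change: a number 0.40 log units higher from compound 1 to compound 2 (beyond the scatter), with hydrogen in place of methoxy on a saturated chain carbon bound to an aromatic carbon. That modest step concerns a methoxy on a chain carbon, not on an aromatic carbon, so it guides direction more than size. A downward move of smaller size is therefore expected in this assay. The expected change is a number 0.20 log units lower from compound 2 to compound 3 (within the scatter), so no step beyond the scatter is expected. Compound 3 is estimated at 2.8, within an expected range of 2.5 to 3.1.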

Compound 3, distribution coefficient: 2.7
The estimate for compound 3 lay 0.10 log units above the measured number; the range from low to high includes it.
By their numbers in this assay, from the lowest: compounds 1, 3 and 2 (each within the scatter of the next, the first and the last beyond it).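

On the aromatic carbon ortho to a large group, methoxy in place of methyl gives a number 0.30 log units lower from compound 2 to compound 3 (within the scatter) and so does not separate the two compounds in this assay. Methoxy in place of methoxymethyl on the same carbon gives a number 0.10 log units higher from compound 1 to compound 3 (within the scatter) and does not separate those two either, so compound 3 cannot be placed with one neighbour rather than the other, although the step of a number 0.40 log units higher from compound 1 to compound 2 (beyond the scatter) shows that compound 1 and compound 2 are themselves separated. No measurement at hand offers a reason for these numbers.

Still open, on these data alone, is whether an amine, a carboxylic acid or a longer chain on this aromatic carbon would give a step beyond the scatter in this assay. Also open, as far as these compounds go, is whether methoxy in place of methyl would give a similar step on another carbon of that ring.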